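The source may report more compounds than this note shows. Statements on the series, on what has been measured and on what is new or still open speak of the compounds shown alone.

Working notes on the series. Compound 1 `CCCCNc1nc(N)nc(C)c1CCCN1CCN(C)CC1` is the reference point. Within the data shown here, in an assay on HEK293 cells for agonist activity at Toll-like receptor 8 (Homo sapiens), read by spectrophotometry (on this read-out lower numbers stand for an effect already at smaller amounts and higher numbers for an effect only at larger amounts of compound), compound 1 gives 179 nM, the lowest of the two numbers known so far. Among the measured compounds shown here, compound 2 `CCCCNc1nc(N)nc(C)c1CCCn1cccn1` is the only other measured compound; in this assay compound 2 gives 1050 nM. For the measured compounds named here, the single measured step, a 5.9-fold higher number from compound 1 to compound 2 (0.77 log units; beyond the scatter), replaces the whole saturated ring amine at the chain end with an aromatic ring.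

Compound 3 `CCCCNc1nc(N)nc(C)c1CCCN1CCN(c2ccccc2)CC1` keeps the ring amine of compound 1 and alters only its substituent: phenyl in place of methyl on an amine nitrogen in a ring. Going by the values given here, no measured pair varies this position, so the step from compound 1 to compound 2 bears on it only indirectly, showing that the chain terminus is not indifferent in this assay. A modest upward step is expected, a 2.2-fold higher number from compound 1 to compound 3 (0.35 log units; beyond the scatter), and compound 3 is estimated in this assay at 400 nM, with a range from 120 nM to 1300 nM.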

Compound 3, half-maximal effective concentration: 92 nM
Compound 3: the middle estimate sits 4.3-fold (0.64 log units) above what was measured; the whole stated range lies above it.
By their numbers in this assay, from the lowest: compounds 3 and 1 (each within the scatter of the next); then compound 2.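

Swapping methyl for phenyl on the ring amine nitrogen leaves the read-out in this assay within the scatter (a 1.9-fold lower number from compound 1 to compound 3 (0.29 log units; within the scatter)), so compound 1 and compound 3 cannot be told apart at this position. An aromatic ring is therefore compatible with this read-out when it is carried on the retained ring amine, whereas the step that replaced the whole ring amine with an aromatic ring lies beyond the scatter (a 5.9-fold higher number from compound 1 to compound 2 (0.77 log units; beyond the scatter)). No available evidence explains why compound 3 reads as it does.

Still open, as far as these compounds go, is whether a benzyl group, an acetyl group or a plain hydrogen on this ring nitrogen would keep the number in the same range. Also open, from the compounds shown here alone, is whether a chlorine or methoxy group on the phenyl ring would move it.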